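Shortening the butyl chain: from compound 1 to compound 4

A few compounds are considered here, and "the series" means these few. Any claim that something is new, unique, unknown or untested is made for them only; others in the source may bear on it.

Values in a functional assay (spleen, spleen) for activation, with Mus musculus as the target; a higher number here means that more compound is needed for the effect, a lower number that less compound is needed:
compound 1 `CCCCc1nc(N)c2nc(O)n(Cc3ccccc3)c2n1`: 0.03 uM
compound 2 `Nc1ncnc2c1nc(O)n2Cc1ccc(Cl)cc1`: 10 uM
compound 3 `COc1nc2c(N)ncnc2n1Cc1ccccc1`: > 10 uM, a limit of the assay, not a number

Compound 1 has the lowest of the two numbers shown, with compound 2 at a number higher by a margin beyond the usual scatter. For compound 3 the value is only a limit (the limit of > 10 uM in this assay, at which 1 of the 3 values shown sits). For the measured compounds named here, no step between two measured compounds that differ in a single place is available.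

Compound 4 `CCCc1nc(N)c2nc(O)n(Cc3ccccc3)c2n1` differs from compound 1 by hydrogen in place of methyl on a saturated chain carbon, three bonds along the chain from an aromatic carbon. With the chain shortened and nothing else altered, a small rise in this assay is expected for compound 4, a 3.3-fold higher number from compound 1 to compound 4 (0.52 log units; beyond the scatter), near the edge of the scatter. The estimate for compound 4 is 0.1 uM, between 0.03 uM and 0.3 uM.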

Compound 4, minimum effective concentration: 1 uM
Compound 4: middle estimate off by 10-fold (1.00 log units), on the low side; the measured number lies above the stated range.
By their numbers in this assay, from the lowest: compound 1; then compound 4; then compound 2.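

In this assay, for the compounds shown here, removing one carbon from the end of the chain, butyl to propyl, gives a 33-fold higher number from compound 1 to compound 4 (1.52 log units; beyond the scatter), the first single-place step in this set, and it shows that this chain position is sensitive to its length. The change involves no ring, no hydrogen-bond donor or acceptor and no net charge, only hydrogen in place of methyl. Nothing measured here accounts for the size of this step.

As far as these compounds go, whether a pentyl or longer chain would lower the number further remains open. So does how an ethyl chain or an ether oxygen within the chain would read.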